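Trifluoromethylphenyl to nitrofuran on the carbonyl: compound 3

The source may report more compounds than this note shows. Statements on the series, on what has been measured and on what is new or still open speak of the compounds shown alone.

In a functional assay on MCF7 cells (Homo sapiens) for antiproliferative activity, read by MTT assay, with a stated time of 72 h (on this read-out lower numbers stand for stronger inhibition and higher numbers for weaker inhibition), compound 1 (`CC1=CC[C@H]2[C@H](CC[C@]2(C)O)C(C)(C)[C@@H]1CC[C@H]1[C@]2(C)CC[C@H](OC(=O)c3cccc(C(F)(F)F)c3)C(C)(C)O[C@H]2CC[C@@]1(C)O`) gives 37900 nM and compound 2 (`CC1=CC[C@H]2[C@H](CC[C@]2(C)O)C(C)(C)[C@@H]1CC[C@H]1[C@]2(C)CC[C@H](OC(=O)c3ccccc3C(F)(F)F)C(C)(C)O[C@H]2CC[C@@]1(C)O`) gives 19200 nM as its read-out. These two numbers lie within the scatter of each other, so compound 2 stands level with compound 1 and holds no real rank. Among the measured compounds shown here, the one measured step (a 2.0-fold lower number from compound 1 to compound 2 (0.30 log units; within the scatter)) puts 2-(trifluoromethyl)phenyl in place of 3-(trifluoromethyl)phenyl on a carbonyl carbon. Compound 3 (`CC1=CC[C@H]2[C@H](CC[C@]2(C)O)C(C)(C)[C@@H]1CC[C@H]1[C@]2(C)CC[C@H](OC(=O)c3ccc([N+](=O)[O-])o3)C(C)(C)O[C@H]2CC[C@@]1(C)O`) keeps the shared core and carries 5-nitrofuran-2-yl in place of 2-(trifluoromethyl)phenyl on a carbonyl carbon. That measured step bears on this change only loosely, since it moves a group within one kind of aryl substituent while the new change replaces the whole substituent. For the measured compounds named here, no measured compound carries a nitrofuran, so the data offer no direction. In this assay no step beyond the scatter is therefore expected, and the estimated change (a 1.0-fold higher number from compound 2 to compound 3 (0.02 log units; within the scatter)) is small against a wide uncertainty. For compound 3 the estimate is 20000 nM with an expected range from 8000 nM to 45000 nM for now.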

Compound 3, half-maximal inhibitory concentration: 21300 nM
Compound 3: the middle estimate sits 1.1-fold (0.03 log units) below what was measured; the range from low to high includes it.
By their numbers in this assay, from the lowest: compounds 2, 3 and 1 (each within the scatter of the next).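

Notes on the carbonyl position: the earlier pair only moved a trifluoromethyl group around a phenyl ring, whereas the nitrofuran exchange replaces the whole substituent, and in this assay both readings of it, a 1.1-fold higher number from compound 2 to compound 3 (0.05 log units; within the scatter) and a 1.8-fold lower number from compound 1 to compound 3 (0.25 log units; within the scatter), stay within the scatter. Among the three compounds shown, a six-membered aromatic ring of carbon only and a five-membered aromatic ring with 1 hetero atom are therefore interchangeable on this carbonyl carbon as far as this read-out can tell, and no compound shown goes against that. No measurement is at hand that would account for this flat result.

From the compounds shown here alone, all three compounds carry an aromatic ring directly on the carbonyl, so it remains open whether a longer alkyl chain, or a ring bearing an amine or a carboxylic acid, would move the number beyond the scatter. Going by these compounds, it is also open whether the acyl group matters at all, since a free hydroxyl on the shared core in place of the whole ester would be needed to show what this position contributes.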